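Shrinking the acetal side chain on a shared core

The compounds below may be only part of what the source reports. "The series", "measured", "known", "first", "only" and "open" are said of these compounds alone.

Compound 1 `Nc1nc2cc(-c3nn(CC4CCCO4)c4ncnc(N)c34)ccc2o1`: 100 nM
Compound 2 `CCOC(Cn1nc(-c2ccc3oc(N)nc3c2)c2c(N)ncnc21)OCC`: 100 nM

Both were tested in a functional assay on T98 cells (Homo sapiens) for antiproliferative activity, with a stated time of 5 days; a higher number here means that more compound is needed for the effect, a lower number that less compound is needed. Compound 2 stands level with compound 1 at the digits shown. For the measured compounds named here, the only measured step, no change at the digits printed from compound 1 to compound 2 (within the scatter), changed the same side group and moved the value by nothing beyond the scatter. Compound 3 `COC(Cn1nc(-c2ccc3oc(N)nc3c2)c2c(N)ncnc21)OC` differs by dimethoxymethyl in place of diethoxymethyl on a saturated chain carbon bound to an aromatic nitrogen, a shorter version of the group in compound 2. Because no change at the digits printed from compound 1 to compound 2 (within the scatter) was flat at this very place, the expected shift no change at the digits printed from compound 2 to compound 3 (within the scatter) is none beyond the scatter. Compound 3 is therefore estimated at 100 nM, with a range from 40 nM to 250 nM.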

Compound 3, half-maximal effective concentration: 100 nM
For compound 3 middle estimate and measured number coincide at the digits printed, and the stated range covers the measured number.
By their numbers in this assay, from the lowest: compounds 1, 2 and 3 (each within the scatter of the next).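

In this assay, shortening the acetal from diethoxymethyl to dimethoxymethyl on a saturated chain carbon bound to an aromatic nitrogen gives no change at the digits printed from compound 2 to compound 3 (within the scatter), so the flat response also holds for this smaller open-chain group. Swapping the ring of oxolan-2-yl directly for dimethoxymethyl gives no change at the digits printed from compound 1 to compound 3 (within the scatter), which places all three side groups on one level. No data here explain this flat response.

All three groups contain ether oxygens, so an amine, a carboxylic acid or a simple longer alkyl chain at this place could behave differently. From the compounds shown here alone, how far this flat response extends therefore remains open.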